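Chloro to methoxy on the pendant phenyl of compound 1

The source may hold more compounds than are shown below. What is called first, only, known or untested is meant among the compounds shown, and "the series" means these compounds.

Measured so far in a functional assay on CAKI-1 cells (Homo sapiens) for cytotoxicity, read by sulforhodamine B assay, with a stated time of 48 h; on this read-out lower numbers stand for stronger inhibition of growth and higher numbers for weaker inhibition of growth:
compound 1, `CC1=C(C(=O)Nc2ccc(F)c(Cl)c2)C(c2cccc(Cl)c2)NC(=S)N1`: 39800 nM
compound 2, `CC1=C(C(=O)Nc2ccc(F)c(Cl)c2)C(c2cccc(Oc3ccccc3)c2)NC(=O)N1`: 10000 nM
compound 3, `CC1=C(C(=O)Nc2ccc(Cl)c(Cl)c2)C(c2ccccc2O)NC(=O)N1`: 39800 nM

Compound 1 stands level with compound 3 at the digits given, the two together forming the highest numbers of the three in this assay; the gap between them lies within the scatter. Compound 2 is the furthest from compound 1, with a lower number that lies beyond the scatter.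

Compound 4, `COc1cccc(C2NC(=S)NC(C)=C2C(=O)Nc2ccc(F)c(Cl)c2)c1`, is not yet measured. It differs from compound 1 in one place: methoxy in place of chloro on an aromatic carbon. Within the data shown here, no pair of measured compounds shows this exact exchange, so the size of the step is not fixed by the data. Compound 2, which carries a different group on the same ring, gives 10000 nM, lower than compound 1, but that exchange is not the one made here.

The expectation for compound 4 is a step of no more than modest size, a 1.3-fold lower number from compound 1 to compound 4 (0.12 log units; within the scatter), in this assay. Compound 4 is estimated at 30000 nM, with a range of 10000 nM to 100000 nM.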

Compound 4, concentration for 50% growth inhibition: 49000 nM
Compound 4: middle estimate off by 1.6-fold (0.21 log units), on the low side; low and high end bracket the measured number.
By their numbers in this assay, from the lowest: compound 2; then compounds 1, 3 and 4 (each within the scatter of the next).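

In this assay the exchange of chloro for methoxy at this aromatic carbon gives a 1.2-fold higher number from compound 1 to compound 4 (0.09 log units; within the scatter) and so does not separate the two groups. Among these compounds, this is the first single-change reading at this position: on the core of compound 1, 3-chlorophenyl and 3-methoxyphenyl cannot be told apart, even though methoxy brings a hydrogen-bond acceptor that chloro lacks. No measurement is available that bears on why the step is this small.

Going by these compounds, whether an amine, a carboxylic acid or a longer chain such as butoxy at this carbon would move the number beyond the scatter remains open. Also open, on these data alone, is whether the same exchange gives a similar step with a carbonyl in place of the thiocarbonyl of the shared core.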